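Replacing the three-membered ring on compound 1 with ethyl

This account rests on a few compounds, and the source may have more. Where it says the series, first, only, none or still open, it means among the compounds named here.

Compound 1 `C[C@@H]1C[C@@H]1C(=O)N1CC2CNCC2C1` gives the highest of the three numbers in an assay on SHEP1 cells for agonist activity at Neuronal acetylcholine receptor; alpha4/beta2 (Homo sapiens), read by FLIPR and calcium flux (on this read-out lower numbers stand for smaller maximal responses and higher numbers for larger maximal responses), at 140%. Compound 2 `C[C@@H]1C[C@H]1C(=O)N1CC2CNCC2C1` gives 100% in this assay, and compound 3 `C[C@H]1C[C@@H]1C(=O)N1CC2CNCC2C1` gives 68%. Both measured steps away from compound 1 are large: a number 40 percentage points lower from compound 1 to compound 2 (beyond the scatter) and a number 72 percentage points lower from compound 1 to compound 3 (beyond the scatter), while a number 32 percentage points lower from compound 2 to compound 3 (beyond the scatter) separates the other two. Compound 4 `CCC(=O)N1CC2CNCC2C1` differs from compound 1 in one place: a group of 2 heavy atoms (2 carbon; no ring) in place of a group of 4 heavy atoms (4 carbon; one three-membered non-aromatic ring of carbon only), on a carbonyl carbon. Each measured step alters only the drawn configuration at the three-membered ring, whereas the step to compound 4 removes that ring with its 2 defined stereocentres altogether, and these steps therefore bear on it only loosely. Still, every change at this ring has lowered the response, and a drop of comparable size is expected, a number 55 percentage points lower from compound 1 to compound 4 (beyond the scatter). Compound 4 is estimated at 85%, with a range from 40% to 130%.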

Compound 4, largest response reached (Emax), in percent of the reference or control that the assay uses: 120%
For compound 4 the middle estimate is 35 percentage points below the measured one; the range from low to high includes it.
By their numbers in this assay, from the lowest: compound 3; then compound 2; then compound 4; then compound 1.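

Without the three-membered ring, the response in this assay stays high on this carbonyl carbon, with a number 20 percentage points lower from compound 1 to compound 4 (beyond the scatter) on removing the whole ring. Ethyl also stands above two of the three 2-methylcyclopropyl forms, with a number 20 percentage points higher from compound 2 to compound 4 (beyond the scatter) and with a number 52 percentage points higher from compound 3 to compound 4 (beyond the scatter) in its favour, so only the configuration drawn in compound 1 places the ring above ethyl. Nothing given here explains why ethyl behaves this way.

Going by these compounds, it remains open whether propyl or a longer chain would exceed ethyl. Unsubstituted cyclopropyl could also show whether the ring or its methyl matters more.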